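This account rests on a few compounds, and the source may have more. Where it says the series, first, only, none or still open, it means among the compounds named here.

Measured so far:
- Compound 1, `N#Cc1ccc(Nc2nc(N)nc(Oc3ccc4ccccc4c3)n2)cc1`, gives 42200 nM in an ADME assay on MT4 cells (Homo sapiens) for cytotoxicity, read by MTT assay, with a stated time of 4 days; a higher number here means that more compound is tolerated, a lower number that less compound is tolerated.
- Compound 2, `CNc1nc(Nc2ccc(C#N)cc2)nc(Oc2ccc3ccccc3c2Br)n1`, gives 143000 nM in this assay.

Compound 2 holds the highest of the two numbers; its nearest neighbour is compound 1, whose number is lower by a gap that lies beyond the scatter. Compound 3, `N#Cc1ccc(Nc2nc(N)nc(Oc3ccc4ccccc4c3Br)n2)cc1`, has not yet been measured in this assay. It differs from compound 2 in one place: hydrogen in place of methyl on a nitrogen on an aromatic ring. For the measured compounds named here, no step between two measured compounds that differ only in this place is available, so the size of this step cannot be read from a precedent. A small change of this kind is expected to move the number little, if at all, beyond the scatter, with the direction left open. For compound 3 the expected value is 90000 nM, with a range from 30000 nM to 250000 nM, which corresponds to an expected step of a 1.6-fold lower number from compound 2 to compound 3 (0.20 log units; within the scatter).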

Compound 3, half-maximal cytotoxic concentration: 133000 nM
For compound 3 the middle estimate is 1.5-fold (0.17 log units) below the measured one; measured number inside the range.
By their numbers in this assay, from the lowest: compound 1; then compounds 3 and 2 (each within the scatter of the next).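

In this assay, the exchange of methylamino for amino on the shared core gives a step that lies within the scatter (a 1.1-fold lower number from compound 2 to compound 3 (0.03 log units; within the scatter)), so the methyl on this nitrogen makes no readable difference in this pair. Compound 3 also isolates the bromo in place of hydrogen on an aromatic carbon, and this single change gives a modest step beyond the scatter (a 3.2-fold higher number from compound 1 to compound 3 (0.50 log units; beyond the scatter)). No measurement shown gives a reason for either step.

As far as these compounds go, it remains open whether chloro or methoxy on that aromatic carbon would give a step like that of bromo, and whether ethylamino on that nitrogen would also stay within the scatter. Each step rests on one pair of compounds, so neither can be extended to other compounds.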